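A few compounds are considered here, and "the series" means these few. Any claim that something is new, unique, unknown or untested is made for them only; others in the source may bear on it.

Three compounds have been run in an ADME assay on cells (Homo sapiens) for cytotoxicity, read by polymerase chain reaction, with a stated time of 3 days; on this read-out lower numbers stand for higher toxicity in this test and higher numbers for lower toxicity in this test:
compound 1 `Nc1nc(Cl)c(-c2ccco2)c(N[C@@H]2C[C@H](CO)[C@@H](O)[C@H]2O)n1`: > 25000 nM, a limit of the assay rather than a number
compound 2 `CNc1ccc2nc(-c3c(Cl)nc(N)nc3N[C@@H]3C[C@H](CO)[C@@H](O)[C@H]3O)sc2c1`: 6000 nM
compound 3 `Cc1nc(NC(C)C)nc(N[C@@H]2C[C@H](CO)[C@@H](O)[C@H]2O)c1-c1nc2ccccc2s1`: 13000 nM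

Compound 3 stands highest of the two numbers given; compound 2 sits beneath it by a gap that lies beyond the usual scatter. Compound 1 sits at the limit of > 25000 nM in this assay, at which 1 of the 3 values shown sits.

Compound 4 `Cc1nc(Nc2nccs2)nc(N[C@@H]2C[C@H](CO)[C@@H](O)[C@H]2O)c1-c1nc2ccccc2s1` has not yet been measured. It differs from compound 3 in one place: 1,3-thiazol-2-yl in place of isopropyl on a nitrogen on an aromatic ring. Among the compounds with values here, no measured pair carries this change, so the expectation rests on compound 3 alone. The step from compound 3 to compound 4 in this assay is expected to be modest and toward a lower number, a 1.6-fold lower number from compound 3 to compound 4 (0.21 log units; within the scatter). Compound 4 is therefore expected to give about 8000 nM in this assay, with a range from 3000 nM to 25000 nM.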

Compound 4, half-maximal cytotoxic concentration: 15000 nM
Estimate against measurement, compound 4: 1.9-fold (0.27 log units) below; the measured number falls inside the stated range.
By their numbers in this assay, from the lowest: compound 2; then compounds 3 and 4 (each within the scatter of the next). At a limit, above all of these: compound 1.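

In this assay the exchange of isopropyl for 1,3-thiazol-2-yl on a nitrogen on an aromatic ring gives a 1.2-fold higher number from compound 3 to compound 4 (0.06 log units; within the scatter). This first reading of the change shows that a five-membered aromatic ring can stand at this place with the two numbers remaining within the scatter of each other. Nothing measured here accounts for this result. The compounds shown leave open how a phenyl ring, a cyclopropyl group or a longer alkyl chain on the same nitrogen would read, and whether a pyridine ring would read like 1,3-thiazol-2-yl.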